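Adding a second methoxy to compound 2

The compounds below may be only part of what the source reports. "The series", "measured", "known", "first", "only" and "open" are said of these compounds alone.

In a functional assay on A549 cells (Homo sapiens) (a lower number here means that less compound is needed, a higher number that more compound is needed for the effect), compound 1 `Oc1nc(-c2cccc(F)c2)nc2ccccc12` gives 9.8 ug/mL. Compound 2 `COc1cccc(-c2nc(O)c3ccccc3n2)c1` reads > 20 ug/mL, which is a limit of the assay and not a number; it stands at the limit of > 20 ug/mL in this assay, at which 1 of the 2 values shown sits. Going by the values given here, the only measured step, methoxy in place of fluoro on an aromatic carbon, is an at least 2.0-fold higher number from compound 1 to compound 2 (0.30 log units; that floor lies within the scatter). Compound 3 `COc1cccc(-c2nc(O)c3cc(OC)ccc3n2)c1` keeps that methoxy and gains another on the core, methoxy in place of hydrogen on an aromatic carbon. The measured step concerns a different place in the structure and gives only a floor, so it offers weak guidance on size. Only a small upward move in this assay, or none beyond the scatter, is expected, and a further limit reading is likely. The expected change is a step that the limit leaves unreadable from compound 2 to compound 3. Compound 3 is estimated at 25 ug/mL, with an expected range of 10 ug/mL to 60 ug/mL.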

Compound 3, concentration for half-maximal effect: 28.1 ug/mL
Estimate against measurement, compound 3: 1.1-fold (0.05 log units) below; the measured number falls inside the stated range.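

No step can be read from compound 2 to compound 3 in this assay, because compound 2 carries only a limit of the assay and not a number: the limit of > 20 ug/mL in this assay, at which 1 of the 3 values shown sits.

The compounds shown leave open how large the effect of the added methoxy on the core is.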